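This account rests on a few compounds, and the source may have more. Where it says the series, first, only, none or still open, it means among the compounds named here.

In a functional assay for inhibition, with Homo sapiens as the target (on this read-out higher numbers stand for weaker inhibition and lower numbers for stronger inhibition), compound 1 `CCCc1nc(C)c2cnnc(O)n12` gives 56800 nM.
Compound 2 `CNc1nncc2c(C)ncn12` reaches only a limit of this assay, > 48000 nM.
Compound 3 `CC(C)c1ncn2c(O)nncc12` likewise reaches only a limit of this assay, > 48000 nM.

Among the measured compounds shown here, compound 3 therefore stands at the limit of > 48000 nM in this assay, at which 2 of the 3 values shown sit, so its place among the three is known only as a limit, and no step between measured compounds is available to set a scale. Compound 4 `Cc1ncn2c(O)nncc12` differs from compound 3 in one place: methyl in place of isopropyl on an aromatic carbon. For the measured compounds named here, with no measured step to lean on, no shift beyond the scatter is expected in either direction. The step expected is a step that the limit leaves unreadable from compound 3 to compound 4. Compound 4 is accordingly estimated at 60000 nM, within a range from 20000 nM to 200000 nM, and a further limit rather than a number is the likelier outcome.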

Compound 4, half-maximal inhibitory concentration: > 48000 nM
Compound 4 gave a limit, no number; the forecaster's own chance of this, stated with the estimate: 70%; the middle value does not contradict the limit.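

Among the compounds shown here, compound 4 reaches only a limit in this assay, > 48000 nM, so no step linking it to compound 1, compound 2 or compound 3 can be read: the limit of > 48000 nM in this assay, at which 3 of the 4 values shown sit. The compounds shown leave open how large these single changes are and in which direction they run.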